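The source may report more compounds than this note shows. Statements on the series, on what has been measured and on what is new or still open speak of the compounds shown alone.

Three compounds share an amide built from a pyrrolidine ring and a carbon chain that ends in an aromatic group, and all three have been tested in an assay on HEK293 cells for inhibition of N-acylethanolamine-hydrolyzing acid amidase (Rattus norvegicus), read by LC-MS, with a stated time of 30 min; a lower number here means a stronger inhibitor, a higher number a weaker inhibitor. Compound 1 `O=C(CCCCCCc1ccc(Cl)cc1)N1CCCC1` carries a chlorinated phenyl ring at the end of a long chain and gives 34500 nM in this assay. Compound 2 `Cc1ccccc1-c1ccc(CCC(=O)N2CCCC2)cc1` joins two aromatic rings directly to one another. In this assay compound 2 gives > 100000 nM, which is a limit of the measurement and not a number. Compound 3 `O=C(CCC1CCC(c2ccccc2)CC1)N1CCCC1` places a phenyl ring on a saturated six-membered ring and gives 480 nM in this assay, the lower of the two numbers, with the number for compound 1 lying well beyond the usual scatter above it.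

Compound 4 `O=C(CCC1CCC(Oc2ccccc2)CC1)N1CCCC1` is the next compound to be measured. It differs from compound 3 in one place: phenoxy in place of phenyl on a saturated ring carbon. For the measured compounds named here, no measured pair shows this exact change, so the size of the step is open. The change is small, a single added atom between the saturated ring and the aromatic ring, and nothing in the measured compounds points to a large shift in either direction. The step is therefore expected to be modest, a 1.4-fold lower number from compound 3 to compound 4 (0.14 log units; within the scatter), within or close to the usual scatter. Compound 4 is expected to give about 350 nM in this assay, with a likely range from 90 nM to 1500 nM.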

Compound 4, half-maximal inhibitory concentration: 2800 nM
Estimate against measurement, compound 4: 8.0-fold (0.90 log units) below; measured number outside the range, above it.
By their numbers in this assay, from the lowest: compound 3; then compound 4; then compound 1. At a limit, above all of these: compound 2.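

Compound 3 and compound 4 are the first pair shown that differ in one place, which gives the first direct reading of this position in this assay and shows a 5.8-fold higher number from compound 3 to compound 4 (0.77 log units; beyond the scatter) when phenoxy takes the place of phenyl on a saturated ring carbon. The entering group differs from the leaving one by a single oxygen, counted as one hydrogen-bond acceptor, yet the step lies beyond the usual scatter, so this position is sensitive to a small change in the group it carries, and of these two groups phenyl gives the stronger inhibitor. Nothing measured here offers an explanation for this rise in the number.

The compounds shown leave open whether the rise follows the oxygen itself or simply the extra atom, a question that a benzyl group or an anilino group on the same saturated ring carbon would address. Also open, going by these compounds, is how compound 3 would respond to a chlorine on its phenyl ring or to a longer chain, as compound 1 and compound 2 each differ from it in more than one place.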